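A few compounds are considered here, and "the series" means these few. Any claim that something is new, unique, unknown or untested is made for them only; others in the source may bear on it.

Compound 1 `CCN(CC)C(=O)c1ccccc1OCC1=NCCN1` and compound 2 `CCN(CC)C(=O)c1ccccc1OCc1c[nH]cn1` share one core, while compound 3 `c1ccc(N2CCCCC2)c(NCC2=NCCN2)c1` and the still unmeasured compound 4 `c1ccc(N2CCCCC2)c(NCc2c[nH]cn2)c1` share another; the difference between the two cores is not broken down here. In a functional assay for activation of Alpha-1A adrenergic receptor (Homo sapiens) (on this read-out lower numbers stand for an effect already at smaller amounts and higher numbers for an effect only at larger amounts of compound), compound 1 reaches only a limit, < 100000 nM. Compound 2 likewise stops at a limit in this assay, < 100000 nM. The change a group of 5 heavy atoms (3 carbon, 2 nitrogen; one five-membered aromatic ring with 2 hetero atoms) in place of a group of 5 heavy atoms (3 carbon, 2 nitrogen; one five-membered non-aromatic ring with 2 hetero atoms), on a saturated chain carbon bound to an oxygen on an aromatic ring therefore gives a step that the two limits leave unreadable from compound 1 to compound 2, and what keeps the step unreadable is the limit of < 100000 nM in this assay, at which 2 of the 3 values shown sit. Within the data shown here, compound 3 is the one compound with a number in this assay, giving 12.6 nM. Compound 4 carries the same kind of change, (a group of 5 heavy atoms (3 carbon, 2 nitrogen; one five-membered aromatic ring with 2 hetero atoms) in place of a group of 5 heavy atoms (3 carbon, 2 nitrogen; one five-membered non-aromatic ring with 2 hetero atoms), on a saturated chain carbon bound to a nitrogen on an aromatic ring), but on a saturated chain carbon bound to a nitrogen on an aromatic ring rather than to an oxygen, so the two changes are of the same kind and not the same. The pair compound 1 and compound 2 offers no readable size for this change, so the expectation rests on compound 3 at 12.6 nM and on the change itself. For compound 4 the expected step is a 9.5-fold higher number from compound 3 to compound 4 (0.98 log units; beyond the scatter). Compound 4 is thus estimated at 120 nM, in a range expected from 15 nM to 1500 nM.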

Compound 4, half-maximal effective concentration: 50.1 nM
For compound 4 the middle estimate is 2.4-fold (0.38 log units) above the measured one; the measured number falls inside the stated range.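

On the core of compound 3, in this assay, the 1H-imidazol-4-yl group in place of the five-membered non-aromatic ring, on a saturated chain carbon bound to a nitrogen on an aromatic ring, gives a 4.0-fold higher number from compound 3 to compound 4 (0.60 log units; beyond the scatter). This is a single pair on a single core: it gives the size of the change there, but it does not show that a step of this size or direction holds when the same kind of change is carried to another core. The matching change on the core of compound 1, on a saturated chain carbon bound to an oxygen on an aromatic ring, cannot be read, because both values there are limits and not numbers: the limit of < 100000 nM in this assay, at which 2 of the 4 values shown sit.

As far as these compounds go, whether the two cores respond alike to this change therefore remains open. Also open, from the compounds shown here alone, is how this assay would respond to a different group at this place on either core, such as an open-chain amine, a carboxylic acid or a longer carbon chain carrying the 1H-imidazol-4-yl group.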